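Heptyl ureas: triazolyl replaced by pyridyl on the distal ring

The source may hold more compounds than are shown below. What is called first, only, known or untested is meant among the compounds shown, and "the series" means these compounds.

Measured so far:
compound 1 `Cc1cc(C)c(NC(=O)N(Cc2ccc(-c3n[nH]c(C)n3)cc2)C2CCCCCC2)c(C)c1` — 120 nM
compound 2 `O=C(Nc1c(F)cc(F)cc1F)N(Cc1ccc(-c2ccsc2)cc1)C1CCCCCC1` — 23 nM

In an assay on microsomes from intestine for inhibition of acyl-CoA:cholesterol acyltransferase (Oryctolagus cuniculus) (on this read-out higher numbers stand for weaker inhibition and lower numbers for stronger inhibition), compound 1 gives 120 nM, the highest of the two numbers recorded. Among the measured compounds shown here, compound 2 gives 23 nM, a lower number; the two compounds differ in more than one place, so their values show only that compound 2 inhibits more strongly, with the gap beyond the usual scatter.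

Compound 3 `Cc1cc(C)c(NC(=O)N(Cc2ccc(-c3cccnc3)cc2)C2CCCCCC2)c(C)c1` is not yet measured. It differs from compound 1 in one place: pyridin-3-yl in place of 5-methyl-1H-1,2,4-triazol-3-yl on an aromatic carbon. For the measured compounds named here, no pair of measured compounds shows this change alone, so the expectation rests on compound 1 alone and on the spread seen with compound 2. A step toward stronger inhibition of modest size is expected, though a result within the scatter of compound 1 would not surprise. For compound 3 the estimate in this assay is 60 nM, within a range of 20 nM to 180 nM. The expected step is a 2.0-fold lower number from compound 1 to compound 3 (0.30 log units; within the scatter).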

Compound 3, half-maximal inhibitory concentration: 130 nM
Beside the measured number, compound 3's estimate is 2.2-fold (0.34 log units) below it; the measured number falls inside the stated range.
By their numbers in this assay, from the lowest: compound 2; then compounds 1 and 3 (each within the scatter of the next).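

In this assay, on an aromatic carbon para to a large group, pyridin-3-yl in place of 5-methyl-1H-1,2,4-triazol-3-yl gives a 1.1-fold higher number from compound 1 to compound 3 (0.03 log units; within the scatter), so this single pair does not separate the two groups. The change removes the hydrogen-bond donor and replaces a five-membered aromatic ring with a six-membered one, and in this pair neither difference moves the number beyond the scatter. No measurement at hand explains why the two groups read alike.

Going by these compounds, whether a carboxylic acid or a dimethylamino group on this aromatic carbon would stay within the scatter of these two compounds remains open. Also open, on these data alone, is how the group carried at this position by compound 2 would read on the core of compound 1, since compound 2 differs from it in more than one place.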